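The source may report more compounds than this note shows. Statements on the series, on what has been measured and on what is new or still open speak of the compounds shown alone.

Measured compounds:
- compound 1 `CCCCCNC(=O)/N=C(\N)NCCCc1sc(N)nc1C`: 0.78
- compound 2 `Cc1nc(N)sc1CCCN/C(N)=N/C(=O)N[C@@H](C)c1ccccc1`: 1.08
- compound 3 `Cc1ccc(C(C)NC(=O)/N=C(\N)NCCCc2sc(N)nc2C)cc1`: 0.85

In a functional assay on Right cardiac atrium for agonist activity at histamine H2 receptor (Cavia porcellus), with a stated time of 30 min, in the presence of a further agent that is not named here (a higher number here means a larger maximal response, a lower number a smaller maximal response), compound 3 gives the second highest of the three numbers; its nearest neighbour is compound 1, whose value lies within the scatter of it, while compound 2 stands higher by an amount beyond the scatter. The unmeasured compound 4 `Cc1nc(N)sc1CCCN/C(N)=N/C(=O)NC(C)c1ccc(Cl)cc1` differs from compound 3 in one place: chloro in place of methyl on an aromatic carbon.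

Among the measured compounds shown here, the only step measured so far, a number 0.30 higher from compound 1 to compound 2 (beyond the scatter), concerns the group on the amide-type nitrogen and not the substituent on the six-membered aromatic ring of carbon only, so it does not bear directly on this change. For the measured compounds named here, compound 2 and compound 3 differ at that ring, and the values of compound 2 and compound 3 show the unsubstituted ring higher, but no single-place step between them is given. Nothing measured here tells how a chloro in place of a methyl on that ring shifts the maximal response, so no step beyond the scatter is expected in this assay. Compound 4 is therefore expected to give about 0.88, with a range from 0.72 to 1.05. The expected step a number 0.030 higher from compound 3 to compound 4 (within the scatter) lies within the scatter.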

Compound 4, intrinsic activity: the largest response reached, as a fraction of the reference agonist's: 0.93
Compound 4: the middle estimate sits 0.050 below what was measured; the range from low to high includes it.
By their numbers in this assay, from the lowest: compounds 1, 3 and 4 (each within the scatter of the next, the first and the last beyond it); then compound 2.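

In this assay, the change at this place, on an aromatic carbon para to a large group, gives a first direct reading: chloro in place of methyl amounts to a number 0.080 higher from compound 3 to compound 4 (within the scatter) in the maximal response. At this position, then, exchanging one single-heavy-atom group for another, neither with hydrogen-bond donors, hydrogen-bond acceptors or a net charge, does not move the response beyond what repeated measurements would scatter by, whereas the earlier step of a number 0.30 higher from compound 1 to compound 2 (beyond the scatter) concerned the group on the amide-type nitrogen and could say nothing about this ring position. No measurement is available that would explain this result.

The compounds shown leave open what a larger or very different group at this same place, such as an amine, a carboxylic acid or a methoxy group, would do to the maximal response. They also leave open whether a longer chain in place of the methyl on the carbon that carries the ring would change the response in the 4-methylphenyl and 4-chlorophenyl compounds.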